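The compounds below may be only part of what the source reports. "The series", "measured", "known", "first", "only" and "open" are said of these compounds alone.

Compound 1 `c1cncc(N2CCCNCCC2)c1` is the reference point of this small set. In an assay on HEK293 cells for displacement of a labelled ligand from Neuronal acetylcholine receptor; alpha4/beta2 (Homo sapiens) (on this read-out lower numbers stand for stronger inhibition and higher numbers for weaker inhibition), compound 1 gives 0.891 nM, the second highest of the three numbers. Compound 3 `Clc1ncc(N2CCCNCC2)cc1Br` gives 1.41 nM in this assay, which lies within the scatter of the value of compound 1. Compound 2 `C=COc1cc(N2CCCNCCC2)cnc1Br` gives 0.38 nM in this assay, a lower number beyond the scatter; it differs from compound 1 in several places, so no single change can be read from it. Compound 4 `COc1cncc(N2CCCNCCC2)c1` differs from compound 1 by methoxy in place of hydrogen on an aromatic carbon. Among the measured compounds shown here, no measured pair shows this change, so the expected step from compound 1 to compound 4, a 1.3-fold lower number from compound 1 to compound 4 (0.10 log units; within the scatter), is modest and within the scatter. Compound 4 is therefore estimated at 0.7 nM, with a range from 0.25 nM to 2 nM.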

Compound 4, half-maximal inhibitory concentration: 1 nM
For compound 4 the middle estimate is 1.4-fold (0.15 log units) below the measured one; the range from low to high includes it.
By their numbers in this assay, from the lowest: compound 2; then compounds 1, 4 and 3 (each within the scatter of the next).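

In this assay, among the compounds shown here, methoxy in place of hydrogen on an aromatic carbon, two atoms from the ring nitrogen, gives a 1.1-fold higher number from compound 1 to compound 4 (0.05 log units; within the scatter) and is the first single change here that can be read. At this position on the core of compound 1, the added methoxy leaves the number without a change that can be told from the scatter. Nothing available explains this result. On these data alone, whether an amine, a carboxylic acid or a longer chain at this position would also leave the number unchanged remains open.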